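Trifluoromethoxyphenyl in place of fluorophenyl: an expected gain

This account rests on a few compounds, and the source may have more. Where it says the series, first, only, none or still open, it means among the compounds named here.

Compound 1 `C[C@H](c1ccc(C(=O)NCCC(=O)O)cc1)N1C(=O)C(c2cccc(F)c2)=N[C@]12CC[C@@H](C(C)(C)C)CC2`: 490 nM
Compound 2 `C[C@H](c1ccc(C(=O)NCCC(=O)O)cc1)N1C(=O)C(c2ccccc2F)=N[C@]12CC[C@@H](C(C)(C)C)CC2`: 1100 nM

In an assay on CHO cells for displacement of a labelled ligand from Glucagon receptor (Homo sapiens), read by scintillation counting, with a stated time of 60 min (a lower number here means a stronger inhibitor, a higher number a weaker inhibitor), compound 2 gives 1100 nM, the higher of the two numbers, while compound 1 gives 490 nM. Among the compounds with values here, the only measured step, a 2.2-fold higher number from compound 1 to compound 2 (0.35 log units; beyond the scatter), bears on compound 3 `C[C@H](c1ccc(C(=O)NCCC(=O)O)cc1)N1C(=O)C(c2cccc(OC(F)(F)F)c2)=N[C@]12CC[C@@H](C(C)(C)C)CC2` in reverse, since the change is 3-(trifluoromethoxy)phenyl in place of 2-fluorophenyl on a carbon with a double bond to nitrogen, which carries the ring substituent back to where compound 1 carries 3-fluorophenyl. Compound 3 is therefore expected to show a modest decrease, a 2.4-fold lower number from compound 2 to compound 3 (0.39 log units; beyond the scatter), in this assay, with the larger group adding uncertainty. Compound 3 is estimated at 450 nM, in the range 150 nM to 1300 nM.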

Compound 3, half-maximal inhibitory concentration: 330 nM
Compound 3: middle estimate off by 1.4-fold (0.13 log units), on the high side; the measured number falls inside the stated range.
By their numbers in this assay, from the lowest: compounds 3 and 1 (each within the scatter of the next); then compound 2.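

At the carbon with a double bond to nitrogen, 3-(trifluoromethoxy)phenyl in place of 2-fluorophenyl gives a 3.3-fold lower number from compound 2 to compound 3 (0.52 log units; beyond the scatter) in this assay, so this position accepts a group with more heavy atoms than the fluorophenyl groups. Trifluoromethoxy in place of fluoro on the aromatic carbon gives a 1.5-fold lower number from compound 1 to compound 3 (0.17 log units; within the scatter), so the larger group leaves the number unresolved from that of compound 1. No measurement shown explains either step.

The compounds shown leave open how a nitrile or an amine would fare in place of trifluoromethoxy on that aromatic carbon. They also leave open whether trifluoromethoxy would keep this number if it stood where compound 2 carries its fluoro.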